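The compounds below may be only part of what the source reports. "The series", "measured", "known", "first", "only" and "open" are said of these compounds alone.

Measured so far:
Compound 1, `O=C(CN(c1nc(Cl)nc2[nH]cnc12)C1CC1)N[C@@H](CCC(=O)OCc1ccccc1)C(=O)OCc1ccccc1`, gives 52.8%.
Compound 2, `C[C@H](NC(=O)CN(c1nc(Cl)nc2[nH]cnc12)C1CC1)C(=O)O`, gives 48.1%.
Compound 3, `CC(C)[C@H](NC(=O)CN(c1ncnc2c1ncn2C1CCCCO1)C1CC1)C(=O)OCc1ccccc1`, gives 21.8%.

All three numbers come from a functional assay on the whole organism (Tail, strain ICR) with Mus musculus as the target, in the tail flick test, with a stated time of 30 min, at a dose of 25 umol/kg by the oral route; on this read-out higher numbers stand for a stronger effect at the one dose given and lower numbers for a weaker effect. Compound 1 stands highest of the three, but its distance to compound 2 lies within the scatter, so these two cannot be told apart; only compound 3 falls beyond the scatter below compound 1. Compound 3 also carries a different core, so its number offers no guide to changes on the core shared by compounds 1 and 2.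

The unmeasured compound 4, `NC(=O)C[C@H](NC(=O)CN(c1nc(Cl)nc2[nH]cnc12)C1CC1)C(=O)OCc1ccccc1`, keeps the core of compound 1 and differs from it at one place: carbamoyl in place of (benzyloxycarbonyl)methyl on a saturated chain carbon, two bonds along the chain from an amide-type nitrogen and a carbonyl carbon. For the measured compounds named here, no measured pair shows this particular change. The closest guide is compound 2, which differs from compound 1 at more than one place and still gives a number within the scatter of compound 1. On that basis compound 4 is expected to sit close to compound 1, with an expected step of a number 6.8 percentage points lower from compound 1 to compound 4 (within the scatter), which is not expected to exceed the scatter. Compound 4 is therefore estimated at 46%, within a range from 26% to 64%.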

Compound 4, a percentage reported as activity, at one dose (the size of the read-out at that dose, not a potency): 24.4%
Beside the measured number, compound 4's estimate is 21.6 percentage points above it; measured number below the stated range.
By their numbers in this assay, from the lowest: compounds 3 and 4 (each within the scatter of the next); then compounds 2 and 1 (each within the scatter of the next).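

In this assay, carbamoyl in place of (benzyloxycarbonyl)methyl on this saturated chain carbon gives a number 28.4 percentage points lower from compound 1 to compound 4 (beyond the scatter), the only single-place change among these compounds, and it shows that the oral read-out at this dose is sensitive to the group at this position. The change removes a six-membered aromatic ring of carbon only, reduces the group from 11 heavy atoms to 3, and adds a hydrogen-bond donor, so this single step cannot show which of these differences goes with the lower number. No measurement shown here gives a reason for the step.

Going by these compounds, it remains open whether the aromatic ring or the amide matters more: a benzyl amide at this place would keep the ring alongside an amide, while a carboxylic acid in place of the benzyl ester would remove the ring without introducing an amide. A longer chain ending in carbamoyl would further test whether the length of the group, rather than its end, goes with the number.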